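A few compounds are considered here, and "the series" means these few. Any claim that something is new, unique, unknown or untested is made for them only; others in the source may bear on it.

Measured in a functional assay on TSGH cells (Homo sapiens) for inhibition, with a stated time of 72 h; on this read-out lower numbers stand for stronger inhibition and higher numbers for weaker inhibition:
- compound 1 `CCCn1ccc2cc(C(=O)c3cc(OC)c(OC)c(OC)c3)ccc21`: 1500 nM
- compound 2 `COc1cc(C(=O)c2ccc3c(ccn3CC(=O)O)c2)cc(OC)c1OC`: 548 nM
- compound 3 `COc1cc(C(=O)c2ccc3c(ccn3CCC(=O)O)c2)cc(OC)c1OC`: > 10000 nM (a limit)

Compound 3 is known only through a limit of this assay, > 10000 nM. Compound 4 `COc1cc(C(=O)c2ccc3c(ccn3CCN(C)C)c2)cc(OC)c1OC` differs from it in one place: dimethylamino in place of carboxy on a saturated chain carbon, two bonds along the chain from an aromatic nitrogen. In words, dimethylamino stands in place of carboxy on a saturated chain carbon, two bonds along the chain from an aromatic nitrogen.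

Among the compounds with values here, no measured step makes this exact exchange, but three bear on it. The closest is an at least 6.6-fold higher number from compound 1 to compound 3 (0.82 log units; beyond the scatter), where carboxy took the place of methyl at the same position. Read in reverse, this step suggests that removing the carboxy from compound 3 could recover much of what was lost. The step of an at least 18-fold higher number from compound 2 to compound 3 (1.26 log units; beyond the scatter) is large and shows how sensitive the read-out is to the placing of the carboxy. The step of a 2.7-fold lower number from compound 1 to compound 2 (0.44 log units; beyond the scatter) goes the other way, so carboxy does not raise the number at every chain length.

A clearly lower number than that of compound 3 is therefore expected in this assay, landing near compound 1 at 1500 nM. The expected change is an at least 10-fold lower number from compound 3 to compound 4 (1.00 log units; beyond the scatter). For compound 4 the estimated value is 1000 nM, with an expected range of 200 nM to 6000 nM.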

Compound 4, half-maximal inhibitory concentration: 4900 nM
Compound 4: middle estimate off by 4.9-fold (0.69 log units), on the low side, within the range that was stated.
By their numbers in this assay, from the lowest: compound 2; then compound 1; then compound 4. At a limit, above all of these: compound 3.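

At the saturated chain carbon two bonds along the chain from an aromatic nitrogen, dimethylamino in place of carboxy gives, in this assay, an at least 2.0-fold lower number from compound 3 to compound 4 (0.30 log units; that floor lies within the scatter), and this is only a floor, since the carboxy partner is known through a limit. Against methyl at the same carbon, dimethylamino still gives a 3.3-fold higher number from compound 1 to compound 4 (0.51 log units; beyond the scatter), so at this carbon carboxy is not the only group that raises the number relative to methyl. The shorter carboxymethyl chain keeps the lowest number of the set, with an 8.9-fold higher number from compound 2 to compound 4 (0.95 log units; beyond the scatter), so the 2-(dimethylamino)ethyl chain does not reach it.

The compounds shown leave open whether a primary amine or a morpholine ring at this carbon would behave like dimethylamino, and whether dimethylamino on the shorter chain would give a lower number, as carboxy does. Going by these compounds, the true value of compound 3, which is a limit, also stays open, and with it the full size of the exchange from carboxy to dimethylamino.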